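This account rests on a few compounds, and the source may have more. Where it says the series, first, only, none or still open, it means among the compounds named here.

Values in a functional assay on MCF7 cells (Homo sapiens) for cytotoxicity, read by sulforhodamine B assay, with a stated time of 24 h; on this read-out higher numbers stand for weaker inhibition and lower numbers for stronger inhibition:
- compound 1 `N#CCC(=O)N/N=C1\C(=O)Nc2ccc(S(=O)(=O)N3CCOCC3)cc21`: 27700 nM
- compound 2 `N=c1oc2ccccc2cc1C(=O)N/N=C1\C(=O)Nc2ccc(S(=O)(=O)N3CCOCC3)cc21`: 20800 nM
- compound 3 `O=C1Nc2ccc(S(=O)(=O)N3CCOCC3)cc2/C1=N/c1cccc(C(F)(F)F)c1`: 41100 nM

Compound 3, at 41100 nM, gives the highest number of the three, yet it stands within the scatter of both compound 1 and compound 2. Among the compounds with values here, the series so far therefore shows no separation in this assay.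

The next compound is compound 4 `CC(=O)N/N=C1\C(=O)Nc2ccc(S(=O)(=O)N3CCOCC3)cc21`. The change is acetamido in place of 3-(trifluoromethyl)phenyl on a double-bonded nitrogen.

Within the data shown here, two measured steps bear on it. The closer one changes the group at the same place, a 1.5-fold higher number from compound 1 to compound 3 (0.17 log units; within the scatter). The other replaces a group on a carbonyl carbon with a much larger one, a 1.3-fold lower number from compound 1 to compound 2 (0.12 log units; within the scatter). Neither step leaves the scatter, although both exchange groups of clearly different size.

No change beyond the scatter is therefore expected in this assay. The expected step is a 1.4-fold lower number from compound 3 to compound 4 (0.14 log units; within the scatter). For compound 4 the estimated value is 30000 nM, with an expected range of 14000 nM to 60000 nM.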

Compound 4, half-maximal inhibitory concentration: 56000 nM
Estimate against measurement, compound 4: 1.9-fold (0.27 log units) below, within the range that was stated.
By their numbers in this assay, from the lowest: compounds 2, 1, 3 and 4 (each within the scatter of the next, the first and the last beyond it).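

In this assay the first separations in the series appear on the side of the carbonyl carbon: hydrogen in place of cyano on a saturated chain carbon bound to a carbonyl carbon gives a 2.0-fold higher number from compound 1 to compound 4 (0.31 log units; beyond the scatter), and one carbon atom in place of the group of 11 heavy atoms gives a 2.7-fold higher number from compound 2 to compound 4 (0.43 log units; beyond the scatter), both modest. On the double-bonded nitrogen, acetamido in place of 3-(trifluoromethyl)phenyl gives a 1.4-fold higher number from compound 3 to compound 4 (0.13 log units; within the scatter), so even this exchange of a ring-bearing group for one with no ring does not leave the scatter. No supporting data on hand account for these steps.

Still open, from the compounds shown here alone, is whether an amine, a carboxylic acid or a longer chain on that saturated chain carbon would give a number closer to that of compound 1 or of compound 4. Also open, going by these compounds, is whether plain phenyl on the double-bonded nitrogen would stay within the scatter of compound 3.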